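A few compounds are considered here, and "the series" means these few. Any claim that something is new, unique, unknown or untested is made for them only; others in the source may bear on it.

Compound 3 `CN1CCN(CCCCOc2c(OCc3ccccc3)cc(O)c3c(=O)cc(-c4ccccc4)oc23)CC1` gives 2930 nM in a functional assay on MCF7 cells (Homo sapiens) for cytotoxicity, read by MTT assay, with a stated time of 72 h (on this read-out lower numbers stand for stronger inhibition and higher numbers for weaker inhibition), the second highest of the three numbers. Compound 2 `CN(C)CCCCOc1c(OCc2ccccc2)cc(O)c2c(=O)cc(-c3ccccc3)oc12` with 3210 nM lies within the scatter of it, as a 1.1-fold lower number from compound 2 to compound 3 (0.04 log units; within the scatter) shows, while compound 1 `CN1CCN(CCCOc2c(OCc3ccccc3)cc(O)c3c(=O)cc(-c4ccccc4)oc23)CC1` with 1020 nM sits lower, shown by a 2.9-fold higher number from compound 1 to compound 3 (0.46 log units; beyond the scatter). Compound 4 `CN1CCN(CCCCOc2c(OCc3nc4ccccc4s3)cc(O)c3c(=O)cc(-c4ccccc4)oc23)CC1` differs from compound 3 by 1,3-benzothiazol-2-yl in place of phenyl on a saturated chain carbon bound to an oxygen on an aromatic ring. Going by the values given here, none of the measured steps touches this place: a 3.1-fold higher number from compound 1 to compound 2 (0.50 log units; beyond the scatter) and the two other steps all concern the amine, not the benzyloxy group. The data thus give no direction for this change. Compound 4 is therefore expected to stay close, the expected step being a 1.2-fold lower number from compound 3 to compound 4 (0.07 log units; within the scatter), not beyond the scatter. Compound 4 is estimated at 2500 nM in this assay, between 800 nM and 8000 nM.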

Compound 4, half-maximal inhibitory concentration: 4850 nM
Compound 4: the middle estimate sits 1.9-fold (0.29 log units) below what was measured; the measured number falls inside the stated range.
By their numbers in this assay, from the lowest: compound 1; then compounds 3, 2 and 4 (each within the scatter of the next).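

In this assay, the first change away from the amine, 1,3-benzothiazol-2-yl in place of phenyl on the saturated chain carbon bound to an oxygen on an aromatic ring, gives a 1.7-fold higher number from compound 3 to compound 4 (0.22 log units; within the scatter). At this position, then, the added five-membered aromatic ring with its 2 hydrogen-bond acceptors leaves the number within the scatter. No measured evidence accounts for this result.

Still open, from the compounds shown here alone, is how a pyridin-2-ylmethyl or 4-fluorobenzyl group would read on this oxygen. Also open, going by these compounds, is whether the 1,3-benzothiazol-2-yl step holds on the shorter chain of compound 1 or with the dimethylamino group of compound 2.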